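The compounds below may be only part of what the source reports. "The series", "measured", "known", "first", "only" and "open" are said of these compounds alone.

In a functional assay on SMMC-7721 cells (Homo sapiens) for antiproliferative activity, read by MTT assay, with a stated time of 72 h (on this read-out lower numbers stand for stronger inhibition and higher numbers for weaker inhibition), compound 3 `Cc1ccccc1Oc1c(/C=N\CCCCCCOc2cc3oc(=O)cc(C)c3cc2Cl)c(C)nn1C` gives 5120 nM. Compound 1 `Cc1nn(C)c(Oc2cccc(Cl)c2)c1/C=N\CCCCCCOc1cc2oc(=O)cc(C)c2cc1Cl` gives 5260 nM, and compound 2 `Cc1nn(C)c(Oc2ccc(I)cc2)c1/C=N\CCCCCCOc1cc2oc(=O)cc(C)c2cc1Cl` gives 13300 nM. The step of a 1.0-fold lower number from compound 1 to compound 3 (0.01 log units; within the scatter) places compound 3 alongside compound 1, while the step of a 2.6-fold lower number from compound 2 to compound 3 (0.41 log units; beyond the scatter) sets it apart from compound 2. Compound 4 `Cc1ccc(Oc2c(/C=N\CCCCCCOc3cc4oc(=O)cc(C)c4cc3Cl)c(C)nn2C)cc1` differs from compound 3 by 4-methylphenyl in place of 2-methylphenyl on an oxygen on an aromatic ring. Among the measured compounds shown here, no measured step exchanges 2-methylphenyl for 4-methylphenyl, so the only guidance comes from other exchanges at the same oxygen: a 2.5-fold higher number from compound 1 to compound 2 (0.40 log units; beyond the scatter) was a modest rise, and a 1.0-fold lower number from compound 1 to compound 3 (0.01 log units; within the scatter) stayed within the scatter. Changes at this position have therefore given either no movement or a modest one, and the direction is not settled by the data. A step of modest size at most is expected for compound 4, with no firm direction. Compound 4 is therefore expected to give 6000 nM, with a range from 2500 nM to 15000 nM. The step of a 1.2-fold higher number from compound 3 to compound 4 (0.07 log units; within the scatter) is estimated to fall within the scatter.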

Compound 4, half-maximal inhibitory concentration: 18600 nM
Compound 4: the middle estimate sits 3.1-fold (0.49 log units) below what was measured, outside the stated range (above it).
By their numbers in this assay, from the lowest: compounds 3 and 1 (each within the scatter of the next); then compounds 2 and 4 (each within the scatter of the next).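

The step of a 3.6-fold higher number from compound 3 to compound 4 (0.56 log units; beyond the scatter) in this assay shows that this position responds to where the methyl sits on the phenyl ring, even though the two compounds have the same atoms. Methyl in place of iodo on an aromatic carbon gives a 1.4-fold higher number from compound 2 to compound 4 (0.15 log units; within the scatter), so the 4-methylphenyl and 4-iodophenyl compounds cannot be told apart here. The step of a 3.5-fold higher number from compound 1 to compound 4 (0.55 log units; beyond the scatter) then separates 4-methylphenyl from 3-chlorophenyl, so the four compounds fall into two groups, with the 4-methylphenyl and 4-iodophenyl compounds higher and the 2-methylphenyl and 3-chlorophenyl compounds lower, and none of the four goes against this.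

The data shown offer no explanation for this split. As far as these compounds go, it also remains open whether an amine or a carboxylic acid in place of the methyl would fall with the lower pair or the higher pair.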